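The source may hold more compounds than are shown below. What is called first, only, known or untested is meant among the compounds shown, and "the series" means these compounds.

Going by the values given here, compound 3 `CC(Oc1ccc(Oc2ccc(F)cc2)cc1)C(=O)Cn1nnc(-c2ccc(C(=O)O)cc2)n1` is one of three compounds measured in an assay on microsomes from brain for inhibition of Fatty-acid amide hydrolase 1 (Rattus norvegicus), read by fluorescence and HPLC, with a stated time of 60 min (on this read-out lower numbers stand for stronger inhibition and higher numbers for weaker inhibition), where compound 3 gives 100 nM. Its nearest neighbour is compound 2 `CCCCCCCCc1ccc(OC(C)C(=O)Cn2nnc(-c3ccc(C(=O)O)cc3)n2)cc1`, which gives 50 nM; the furthest is compound 1 `CC(Oc1ccc(Oc2ccc(C(F)(F)F)cc2)cc1)C(=O)Cn1nnc(-c2ccc(Cl)cc2)n1`, which gives 300 nM. Compound 4 `CC(Oc1ccc(Oc2ccc(C(F)(F)F)cc2)cc1)C(=O)Cn1nnc(-c2ccc(C(=O)O)cc2)n1` differs from compound 3 only in trifluoromethyl in place of fluoro on an aromatic carbon. Among the compounds with values here, no measured pair shows this exact exchange; compound 1 also carries a 4-(trifluoromethyl)phenoxy group but differs from compound 4 elsewhere, so its value alone cannot fix the size of the step. Within the data shown here, the one measured change at the same end of the molecule, a 2.0-fold higher number from compound 2 to compound 3 (0.30 log units; within the scatter), stayed within the scatter, so the step is expected to be no change at the digits printed from compound 3 to compound 4 (within the scatter). Compound 4 is therefore estimated at 100 nM, with a range of 40 nM to 250 nM.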

Compound 4, half-maximal inhibitory concentration: 160 nM
The estimate for compound 4 lay 1.6-fold (0.20 log units) below the measured number; the measured number falls inside the stated range.
By their numbers in this assay, from the lowest: compounds 2, 3, 4 and 1 (each within the scatter of the next, the first and the last beyond it).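

At this position, trifluoromethyl in place of fluoro gives a 1.6-fold higher number from compound 3 to compound 4 (0.20 log units; within the scatter) and so adds no change that can be told from the scatter. Setting 4-(trifluoromethyl)phenoxy in place of octyl gives a 3.2-fold higher number from compound 2 to compound 4 (0.51 log units; beyond the scatter) and is the first step at this position to pass the scatter. Elsewhere in the molecule, carboxy in place of chloro gives a 1.9-fold lower number from compound 1 to compound 4 (0.27 log units; within the scatter) and links compound 1 to the others through a single change for the first time.

As far as these compounds go, how an amine or a shorter chain would fare at this position remains open. Nothing shown here explains these steps.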